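Ester variation on the shared core: pyridyl to fluorinated phenyl

A few compounds are considered here, and "the series" means these few. Any claim that something is new, unique, unknown or untested is made for them only; others in the source may bear on it.

Three members of the series have been run in a functional assay on MCF7 cells (Homo sapiens) for antiproliferative activity, read by MTT assay, with a stated time of 72 h; a lower number here means a stronger inhibitor, a higher number a weaker inhibitor. Compound 1 `CC(=O)O[C@H]1CC[C@]2(C)[C@H](CC[C@@](C)(O)[C@H]2CC[C@@H]2C(C)=CC[C@H]3[C@H](CC[C@]3(C)OC(C)=O)C2(C)C)OC1(C)C` gives 39200 nM. Compound 2 `CC1=CC[C@H]2[C@H](CC[C@]2(C)O)C(C)(C)[C@@H]1CC[C@H]1[C@]2(C)CC[C@H](OC(=O)c3ccncc3)C(C)(C)O[C@H]2CC[C@@]1(C)O` gives 25300 nM, and compound 2 and compound 1 lie within the usual scatter of each other, so neither can be placed ahead of the other. Going by the values given here, compound 3 `CC1=CC[C@H]2[C@@H]1CC=C(C)[C@@H](CC[C@H]1[C@]3(C)CC[C@H](OC(=O)CCC(=O)O)C(C)(C)O[C@H]3CC[C@@]1(C)O)C2(C)C` returns only a limit, > 50000 nM, and so offers no number to compare; this is the one value sitting at the limit of > 50000 nM in this assay, at which 1 of the 3 values shown sits. Among the compounds with values here, no pair among the measured compounds differs in a single place, so no measured step is available for the series.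

Compound 4 `CC1=CC[C@H]2[C@H](CC[C@]2(C)O)C(C)(C)[C@@H]1CC[C@H]1[C@]2(C)CC[C@H](OC(=O)c3ccc(C(F)(F)F)cc3F)C(C)(C)O[C@H]2CC[C@@]1(C)O` is the next compound and differs from compound 2 in one place: 2-fluoro-4-(trifluoromethyl)phenyl in place of pyridin-4-yl on a carbonyl carbon. Within the data shown here, with no measured step of this kind to lean on, the expected change is taken as small: the estimated step is a 1.3-fold lower number from compound 2 to compound 4 (0.10 log units; within the scatter), no larger than the scatter. Compound 4 is expected to give an estimated 20000 nM in this assay, with the estimate ranging between 8000 nM and 50000 nM.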

Compound 4, half-maximal inhibitory concentration: > 50000 nM
Compound 4 was reported as a limit; the forecaster's own chance of this, stated with the estimate: 25%; middle value at least 2.5-fold (0.39 log units) away from the limit.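

In this assay, going by these compounds alone, putting 2-fluoro-4-(trifluoromethyl)phenyl in place of pyridin-4-yl on a carbonyl carbon gives the first single-place step, an at least 1.9-fold higher number from compound 2 to compound 4 (0.29 log units; that floor lies within the scatter). Only the floor of this step is known, so it does not establish a change beyond the scatter, but the fluorinated phenyl ester shows no gain over the pyridyl ester at this position. Compound 4 returns only a limit, and one other compound shown shares it: the limit of > 50000 nM in this assay, at which 2 of the 4 values shown sit.

Going by these compounds, how far compound 4 lies past that limit stays open, and with it the true size of the step. Also open, on these data alone, is whether the swap's outcome follows the loss of the ring nitrogen or the arrival of the fluorine and trifluoromethyl groups, a question that an unsubstituted phenyl or an aminophenyl ester on the shared core would help to separate.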